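The source may report more compounds than this note shows. Statements on the series, on what has been measured and on what is new or still open speak of the compounds shown alone.

Compound 1 `C[C@H]1CC[C@@H]2[C@@H](OC(=O)[C@]23CC(c2c(Cl)cccc2Cl)=NO3)[C@]2(C)C(=O)C=C[C@@]12O`: 43000 nM
Compound 2 `COc1ccc(C2=NO[C@]3(C2)C(=O)O[C@@H]2[C@H]3CC[C@H](C)[C@]3(O)C=CC(=O)[C@@]23C)cc1`: 41000 nM
Compound 3 `C[C@H]1CC[C@@H]2[C@@H](OC(=O)[C@]23CC(c2ccc(F)cc2)=NO3)[C@]2(C)C(=O)C=C[C@@]12O`: 3600 nM

In a functional assay on SW-620 cells (Homo sapiens) for cytotoxicity, read by sulforhodamine B assay, with a stated time of 48 h (a higher number here means a weaker inhibitor, a lower number a stronger inhibitor), compound 2 gives 41000 nM, the second highest of the three numbers; compound 1 sits close to it, while compound 3 lies well apart, the gap shown by an 11-fold lower number from compound 2 to compound 3 (1.06 log units; beyond the scatter). Compound 4 `C[C@H]1CC[C@@H]2[C@@H](OC(=O)[C@]23CC(c2ccc(C#N)cc2)=NO3)[C@]2(C)C(=O)C=C[C@@]12O` is not yet measured. It differs from compound 2 by cyano in place of methoxy on an aromatic carbon.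

Among the measured compounds shown here, two measured steps bear on this. The step of a 1.0-fold lower number from compound 1 to compound 2 (0.02 log units; within the scatter) shows one exchange of the aryl group leaving the number unchanged, whereas an 11-fold lower number from compound 2 to compound 3 (1.06 log units; beyond the scatter), an exchange at the very same aromatic carbon, gave a large drop. Cyano has not been tried; a moderate lowering is therefore expected, a 2.7-fold lower number from compound 2 to compound 4 (0.44 log units; beyond the scatter), with wide uncertainty.

Compound 4 is estimated at 15000 nM, between 4000 nM and 45000 nM.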

Compound 4, half-maximal inhibitory concentration: 53000 nM
Beside the measured number, compound 4's estimate is 3.5-fold (0.55 log units) below it; the whole stated range lies below it.
By their numbers in this assay, from the lowest: compound 3; then compounds 2, 1 and 4 (each within the scatter of the next).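

In this assay, replacing methoxy with cyano gives a 1.3-fold higher number from compound 2 to compound 4 (0.11 log units; within the scatter) and so does not follow fluoro, while the change of the whole aryl group gives a 1.2-fold higher number from compound 1 to compound 4 (0.09 log units; within the scatter) as well. Fluoro stands alone here, since cyano in its place gives a 15-fold higher number from compound 3 to compound 4 (1.17 log units; beyond the scatter) at the same carbon. Nothing shown here explains why these two groups differ.

Going by these compounds, whether an amine or a carboxylic acid at this carbon would go with compound 3 or with compounds 1, 2 and 4 remains open. So does the effect of a longer chain there.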